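Replacing Hydroxy with Aminopropyl on the Amide Tail

The compounds below may be only part of what the source reports. "The series", "measured", "known", "first", "only" and "open" are said of these compounds alone.

Of the compounds shown here, three sharing one core have been measured in an assay on L1.2 cells for binding affinity to C-C chemokine receptor type 8 (Homo sapiens); on this read-out lower numbers stand for stronger inhibition and higher numbers for weaker inhibition. Compound 1 `CCOC(=O)N1CCC(NS(=O)(=O)c2ccc(NCCCc3ccccc3)c3ccccc23)CC1` gives 32.1 nM, and compound 2 `CCOC(=O)N1CCC(NS(=O)(=O)c2ccc(OC(=O)c3ccccc3)c3ccccc23)CC1` gives 16.4 nM. Among the measured compounds shown here, the only one-place step among them, a 2.0-fold lower number from compound 1 to compound 2 (0.29 log units; within the scatter), concerns a change on an aromatic carbon of the core. Compound 3 `Cc1ccccc1C(=O)Nc1ccc(S(=O)(=O)NC2CCN(C(=O)CO)CC2)c2ccccc12` gives 5.4 nM and stands lowest of the three numbers, its gap to compound 2 and its larger gap to compound 1 both lying beyond the scatter.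

Compound 4 `Cc1ccccc1C(=O)Nc1ccc(S(=O)(=O)NC2CCN(C(=O)CCCCN)CC2)c2ccccc12` differs from compound 3 only at the chain attached to the amide carbonyl: 3-aminopropyl in place of hydroxy on a saturated chain carbon bound to a carbonyl carbon. For the measured compounds named here, no measured step touches this part of the molecule; the single measured step sits on the core and therefore offers no guide to the size or direction of this change. With nothing in the data pointing one way, the expectation for this assay is a change from compound 3 that stays close to the scatter, summarised as a 1.1-fold higher number from compound 3 to compound 4 (0.05 log units; within the scatter). Compound 4 is accordingly estimated at 6 nM, with a range from 2 nM to 20 nM, the width reflecting that the change is unprecedented among the measured compounds.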

Compound 4, inhibition constant: 199 nM
Estimate against measurement, compound 4: 33-fold (1.52 log units) below; measured number outside the range, above it.
By their numbers in this assay, from the lowest: compound 3; then compounds 2 and 1 (each within the scatter of the next); then compound 4.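

Measured in this assay the chain attached to the amide carbonyl turns out to be a sensitive place, with 3-aminopropyl in place of hydroxy giving a large step (a 37-fold higher number from compound 3 to compound 4 (1.57 log units; beyond the scatter)). Among the compounds shown here, the only earlier step sat on an aromatic carbon of the core and stayed within the scatter (a 2.0-fold lower number from compound 1 to compound 2 (0.29 log units; within the scatter)), so the earlier compounds gave no sign that a change on this saturated chain carbon bound to a carbonyl carbon could move the number so far; the step also shows that matching counts of hydrogen-bond donors and acceptors, with no net charge on either group, do not guarantee a similar number. No measurement available here explains why the number rises so sharply.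

This single step changes both the length of the chain and the group it carries, so it cannot say whether the extra carbons, the amine, or the two together go with the higher number. A plain propyl group with no amine, or a carboxylic acid in place of hydroxy, would help separate these possibilities.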